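Swapping a Bromophenyl Arm for a Fluorophenyl Arm

The compounds below may be only part of what the source reports. "The series", "measured", "known", "first", "only" and "open" are said of these compounds alone.

Compound 1 `C=CCn1c(=O)/c(=C\c2cccc(Br)c2)[nH]c(=O)/c1=C\c1ccccc1OC` carries two aromatic arms on a shared core, one of them a 3-bromophenyl and the other bearing a methoxy group. In a functional assay on MCF7 cells (Homo sapiens) for cytotoxicity, read by CCK-8 assay, with a stated time of 72 h (on this read-out higher numbers stand for weaker inhibition and lower numbers for stronger inhibition), compound 1 gives 5400 nM. On this read-out compound 1 holds the only number shown. Compound 2 `C=CCn1c(=O)/c(=C\c2cccc(Br)c2)[nH]c(=O)/c1=C\c1cccc(Br)c1`, which carries a 3-bromophenyl on both arms, is the one further entry. In this assay compound 2 is recorded as "not active" (no number reported), with no single number attached, so it cannot be placed against compound 1 on a scale.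

Compound 3 `C=CCn1c(=O)/c(=C\c2ccccc2F)[nH]c(=O)/c1=C\c1ccccc1OC` has not yet been measured. It differs from compound 1 in one place: 2-fluorophenyl in place of 3-bromophenyl on a double-bonded chain carbon bound to an aromatic carbon. Within the data shown here, no measured pair in this set shows what such a change does, so the expectation rests on compound 1 alone and is loose. The step from compound 1 to compound 3 is expected to be a 1.5-fold higher number from compound 1 to compound 3 (0.17 log units; within the scatter), a mild weakening that may stay inside the usual scatter. Compound 3 is accordingly estimated at 8000 nM, within a range from 2000 nM to 40000 nM, with a fair chance that this assay reports no number for it at all.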

Compound 3, half-maximal inhibitory concentration: 23000 nM
Compound 3: the middle estimate sits 2.9-fold (0.46 log units) below what was measured; low and high end bracket the measured number.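

Replacing 3-bromophenyl with 2-fluorophenyl on a double-bonded chain carbon bound to an aromatic carbon gives a 4.3-fold higher number from compound 1 to compound 3 (0.63 log units; beyond the scatter) in this assay and so shows that this arm is not a neutral spot on the molecule: the change is modest, but it lies beyond the usual scatter and goes toward weaker inhibition. The two arms have the same count of heavy atoms, the same single six-membered aromatic ring of carbon only, no hydrogen-bond donors or acceptors and no net charge, so a shift appears even though these counted features stay the same. No measurement shown here gives a reason for the shift.

The swap changes both the halogen and the numbered ring position it occupies, so this single pair cannot say which of the two matters, and arms such as 3-fluorophenyl or 2-bromophenyl would pull them apart. Also open, on these data alone, is how this arm would respond to a plain phenyl with no halogen, or to a phenyl carrying an amine or a carboxylic acid.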